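A few compounds are considered here, and "the series" means these few. Any claim that something is new, unique, unknown or untested is made for them only; others in the source may bear on it.

Measured so far:
- compound 1 `O=c1[nH]cnc2c1c(-c1cc3ccccc3o1)cn2[C@@H]1O[C@H](CO)[C@@H](O)[C@H]1O`: > 20000 nM
- compound 2 `Cc1ncnc2c1c(-c1ccsc1)cn2[C@@H]1O[C@H](CO)[C@@H](O)[C@H]1O`: 14300 nM

In a functional assay on HeLa S3 cells (Homo sapiens) for antiproliferative activity, read by XTT assay, with a stated time of 72 h (on this read-out lower numbers stand for stronger inhibition and higher numbers for weaker inhibition), compound 1 gives > 20000 nM, and this is a limit of the assay rather than a measured number, so compound 1 stands at the top of the values shown, as described by the limit of > 20000 nM in this assay, at which 1 of the 2 values shown sits. In this assay compound 2 gives 14300 nM; both compounds are weak inhibitors of cell growth in this assay.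

Compound 3 `O=c1[nH]cnc2c1c(-c1ccoc1)cn2[C@@H]1O[C@H](CO)[C@@H](O)[C@H]1O` is not yet measured. It differs from compound 1 in one place: furan-3-yl in place of 1-benzofuran-2-yl on an aromatic carbon. Among the measured compounds shown here, no step between two measured compounds is recorded for this change, so its size can only be guessed from the weak values of compound 1 and compound 2. The step from compound 1 to compound 3 is expected to be small, a step that the limit leaves unreadable from compound 1 to compound 3, not beyond the scatter in either direction. Compound 3 is therefore expected to give about 25000 nM, within a range of 8000 nM to 80000 nM, with a fair chance that only a limit is reported.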

Compound 3, half-maximal inhibitory concentration: > 20000 nM
Compound 3 was reported as a limit; the forecaster's own chance of this, stated with the estimate: 60%; the middle value does not contradict the limit.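

Among the compounds shown here, compound 1 and compound 3 are both reported only as limits, not as numbers, so no step between them can be read: the limit of > 20000 nM in this assay, at which 2 of the 3 values shown sit. The compounds shown leave open whether furan-3-yl in place of 1-benzofuran-2-yl changes activity in this assay at all, or by how much.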